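Side-chain variation at the amide-linked carbon

The source may report more compounds than this note shows. Statements on the series, on what has been measured and on what is new or still open speak of the compounds shown alone.

Measured in a functional assay for inhibition of Peptidylglycine alpha-amidating monooxygenase (Rattus norvegicus); on this read-out lower numbers stand for stronger inhibition and higher numbers for weaker inhibition:
compound 1 `CSCC[C@H](NC(=O)CCc1ccccc1)C(=O)NC(CCS)C(=O)O` gives 18 nM
compound 2 `CC(C)[C@H](NC(=O)CCc1ccccc1)C(=O)NC(CCS)C(=O)O` gives 160 nM

Going by the values given here, compound 2 stands at the highest of the two numbers in this assay; its only neighbour is compound 1, and the step between them is an 8.9-fold higher number from compound 1 to compound 2 (0.95 log units; beyond the scatter), beyond the scatter. Compound 3 `CCCC[C@H](NC(=O)CCc1ccccc1)C(=O)NC(CCS)C(=O)O` is still to be measured in this assay. Its change from compound 2 is butyl in place of isopropyl on a saturated chain carbon bound to an amide-type nitrogen and a carbonyl carbon. Among the compounds with values here, the one measured step that bears on this place is an 8.9-fold higher number from compound 1 to compound 2 (0.95 log units; beyond the scatter), in which the unbranched 2-(methylsulfanyl)ethyl of compound 1 was exchanged for isopropyl. Butyl, like that chain of compound 1, is unbranched, so the change from compound 2 undoes the branching that accompanied the weakening seen in that step, without restoring the sulfur-bearing chain itself. A move back toward the number of compound 1, though not necessarily all the way, is therefore expected. For compound 3 the expected step is a 3.6-fold lower number from compound 2 to compound 3 (0.55 log units; beyond the scatter). Compound 3 is estimated at 45 nM, with a range from 15 nM to 130 nM.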

Compound 3, half-maximal inhibitory concentration: 23 nM
The estimate for compound 3 lay 2.0-fold (0.29 log units) above the measured number, and the stated range covers the measured number.
By their numbers in this assay, from the lowest: compounds 1 and 3 (each within the scatter of the next); then compound 2.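

In this assay, the step of a 7.0-fold lower number from compound 2 to compound 3 (0.84 log units; beyond the scatter) shows that butyl in place of isopropyl on this saturated chain carbon is enough to reach a number close to that of compound 1, so within these compounds the sulfur of 2-(methylsulfanyl)ethyl is not required for that level of inhibition. The exchange of methylsulfanyl for ethyl on the chain, seen in the step of a 1.3-fold higher number from compound 1 to compound 3 (0.11 log units; within the scatter), leaves the two unbranched side chains indistinguishable on this read-out, and compound 2, the only one carrying isopropyl, is the one set apart from the other two. Nothing available here accounts for the difference between butyl and isopropyl at this position.

Isopropyl differs from butyl in both branching and heavy-atom count, so it remains open which of the two goes with the higher number; an unbranched propyl or a branched sec-butyl group would separate them. Also open, going by these compounds, is how far the side chain can be varied, for example with a longer chain such as hexyl or with an amine or a carboxylic acid at its end.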